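This account rests on a few compounds, and the source may have more. Where it says the series, first, only, none or still open, it means among the compounds named here.

Measured so far in an assay on HEK293 cells for activation of Kir3.1/Kir3.2 (Homo sapiens), read by thallium flux; on this read-out higher numbers stand for larger maximal responses and lower numbers for smaller maximal responses:
compound 1 `Cc1cc(NC(=O)Cn2nnc(-c3ccccc3)n2)n(C2CCCCC2)n1`, 92%
compound 2 `Cc1cc(NC(=O)Cn2nnc(-c3ccccc3)n2)n(C(C)C)n1`, 107%
compound 3 `Cc1cc(NC(=O)Cn2nnc(-c3ccccn3)n2)n(C2CCCCC2)n1`, 81%

Compound 3 stands lowest of these three numbers in this assay. This follows from a number 11 percentage points lower from compound 1 to compound 3 (beyond the scatter), and compound 2 sits higher still, beyond the scatter of both.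

Compound 4 `Cc1cc(NC(=O)Cn2nnc(-c3ccc(Cl)c(Cl)c3)n2)n(C2CCCCC2)n1` differs from compound 3 by 3,4-dichlorophenyl in place of pyridin-2-yl on an aromatic carbon. Among the compounds with values here, the only measured step at this place on the five-membered ring is a number 11 percentage points lower from compound 1 to compound 3 (beyond the scatter), which shows that exchanging the aryl group here shifts the maximal response by a modest amount. Undoing that exchange would bring the number back to roughly the level of compound 1; the two chlorine atoms that enter have no measured counterpart, so their contribution is unknown. The other step, a number 15 percentage points higher from compound 1 to compound 2 (beyond the scatter), concerns the group on the ring nitrogen and does not bear on this change. Compound 4 is therefore expected to show a modest rise, a number 9 percentage points higher from compound 3 to compound 4 (within the scatter). The estimate for compound 4 is 90%, with a range from 72% to 108%.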

Compound 4, largest response reached (Emax), in percent of the reference or control that the assay uses: 84%
Compound 4: middle estimate off by 6 percentage points, on the high side; measured number inside the range.
By their numbers in this assay, from the lowest: compounds 3, 4 and 1 (each within the scatter of the next, the first and the last beyond it); then compound 2.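

Setting 3,4-dichlorophenyl in place of pyridin-2-yl gives a number 3 percentage points higher from compound 3 to compound 4 (within the scatter) and setting it in place of phenyl gives a number 8 percentage points lower from compound 1 to compound 4 (within the scatter) on the same core. So this aromatic carbon of the ring with four nitrogen atoms takes an aryl group with two chlorine atoms and shows no clear separation from either parent compound, even though compound 1 and compound 3 do differ beyond the scatter. Nothing available explains this behaviour at the position.

Still open, going by these compounds, is whether a phenyl ring carrying a carboxylic acid, an amine or a methoxy group at this place would keep the maximal response. Also open, on these data alone, is whether 3,4-dichlorophenyl gives a similar number with isopropyl in place of cyclohexyl on the aromatic nitrogen.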